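Moving a Fluorine Atom on a Shared Core

The source may report more compounds than this note shows. Statements on the series, on what has been measured and on what is new or still open speak of the compounds shown alone.

Compound 1 `CC(=O)Nc1ccc2oc(-c3ccccc3F)cc(=O)c2c1`: in an ADME assay on THP-1 cells (Homo sapiens) for cytotoxicity, read by flow cytometry and propidium iodide staining, with a stated time of 72 h (on this read-out lower numbers stand for stronger inhibition and higher numbers for weaker inhibition), compound 1 gives > 125000 nM, which is a limit of the assay rather than a number.
Compound 2 `CC(=O)Nc1ccc2oc(-c3cccc(F)c3)cc(=O)c2c1`: in this assay compound 2 gives > 125000 nM, also a limit.
Compound 3 `COc1c(-c2ccccc2F)oc2ccc(N)cc2c1=O`: in this assay compound 3 gives > 125000 nM, again a limit.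

The change from compound 1 to compound 2 is 3-fluorophenyl in place of 2-fluorophenyl on an aromatic carbon. Its step is a step that the two limits leave unreadable from compound 1 to compound 2, since both values sit at the limit of > 125000 nM in this assay, at which 3 of the 3 values shown sit. Compound 4 `COc1c(-c2cccc(F)c2)oc2ccc(N)cc2c1=O` is not yet measured and arises from compound 3 by 3-fluorophenyl in place of 2-fluorophenyl on an aromatic carbon, the same kind of change, though here the place is also ortho to a methoxy group (2 heavy atoms). The difference between the two cores is not broken down here. Because compound 3 gives > 125000 nM and the earlier step stayed unreadable, compound 4 is expected to sit at the limit as well. The expected step is a step that the limit leaves unreadable from compound 3 to compound 4. The estimate for compound 4 is 200000 nM, within 100000 nM to 500000 nM.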

Compound 4, half-maximal inhibitory concentration: 34000 nM
Compound 4: middle estimate off by 5.9-fold (0.77 log units), on the high side; measured number below the stated range.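

In this assay, moving the fluorine from 2-fluorophenyl to 3-fluorophenyl on the core of compound 3 gives an at least 3.6-fold lower number from compound 3 to compound 4 (0.56 log units; beyond the scatter). Going by these compounds, the same change on the core of compound 1 cannot be read, so it remains unknown whether the shift carries from one core to the other, because both values on that core rest on a limit: the limit of > 125000 nM in this assay, at which 3 of the 4 values shown sit. This makes the step a single readable case on one core, not a rule for the series, and it gives no reason for the shift.

On these data alone, it remains open whether the shift would persist with chlorine in place of the fluorine, or with an ethoxy group in place of the methoxy group. The compounds shown also do not separate which difference between the two cores matters.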